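The compounds below may be only part of what the source reports. "The series", "measured", "known", "first", "only" and "open" are said of these compounds alone.

Measured compounds:
compound 1 `COc1cc(O)c(C(=O)/C=C/c2ccc(N3CCNCC3)cc2)c(OC)c1` — 67500 nM
compound 2 `COc1cc(OC)c(C(=O)/C=C/c2cccc(N3CCNCC3)c2)c(O)c1CC=C(C)C` — 99900 nM
compound 3 `COc1cc(O)c(C(=O)/C=C/c2ccc(N3CCN(C(=O)OC(C)(C)C)CC3)cc2)c(OC)c1` — 47300 nM

In an ADME assay on MCF7-DOX cells (Homo sapiens) for cytotoxicity, read by MTT assay, with a stated time of 48 h (on this read-out lower numbers stand for stronger inhibition and higher numbers for weaker inhibition), compound 1 gives 67500 nM and compound 3 gives 47300 nM. Compound 3 differs from compound 1 by tert-butoxycarbonyl in place of hydrogen on an amine nitrogen in a ring; the step it made is a 1.4-fold lower number from compound 1 to compound 3 (0.15 log units; within the scatter). Compound 2 gives 99900 nM in this assay. The difference between the core of compound 2 and the core of compound 1 is not broken down here.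

Compound 4 `COc1cc(OC)c(C(=O)/C=C/c2cccc(N3CCN(C(=O)OC(C)(C)C)CC3)c2)c(O)c1CC=C(C)C` has not yet been measured. It differs from compound 2 by tert-butoxycarbonyl in place of hydrogen on an amine nitrogen in a ring, the same change as from compound 1 to compound 3, at a place described in the same words. Among the measured compounds shown here, the step from compound 2 to compound 4 is expected to be about as small as the one from compound 1 to compound 3, because a 1.4-fold lower number from compound 1 to compound 3 (0.15 log units; within the scatter) was within the scatter; the expected step is a 1.4-fold lower number from compound 2 to compound 4 (0.14 log units; within the scatter). Compound 4 is thus estimated at 72000 nM in this assay, with a range from 35000 nM to 150000 nM.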

Compound 4, half-maximal inhibitory concentration: 42600 nM
For compound 4 the middle estimate is 1.7-fold (0.23 log units) above the measured one; the range from low to high includes it.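

In this assay, tert-butoxycarbonyl in place of hydrogen on an amine nitrogen in a ring gives a 2.3-fold lower number from compound 2 to compound 4 (0.37 log units; beyond the scatter) and points the same way on both cores, with no difference between the steps beyond the scatter: the same change on two cores in this assay, a 1.4-fold lower number (0.15 log units; within the scatter) from compound 1 to compound 3 and a 2.3-fold lower number (0.37 log units; beyond the scatter) from compound 2 to compound 4, 1.6-fold (0.22 log units) apart, within the scatter of two such steps. Among the compounds shown here, the change therefore carries from the core of compound 1 to the core of compound 2 without a detectable shift in size, but this rests on only two pairs. Only the second step lies beyond the scatter, so a real gain on both cores is not shown, and neither is transfer to any other core.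

Open, from the compounds shown here alone, is whether this step is specific to tert-butoxycarbonyl or would also follow from another group on the same nitrogen. An acetyl or a methyl group there would separate the two cases.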